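Cyano to methyl: the step from compound 2 to compound 4

The source may hold more compounds than are shown below. What is called first, only, known or untested is meant among the compounds shown, and "the series" means these compounds.

Measured so far:
compound 1 `S=C(N/N=C/c1ccc2ccccc2n1)Nc1ccc(Br)cc1` gives 56800 nM in a functional assay on HeLa cells (Homo sapiens) for antiproliferative activity, read by sulforhodamine B assay, with a stated time of 72 h; a higher number here means a weaker inhibitor, a lower number a stronger inhibitor
compound 2 `N#Cc1ccc(NC(=S)N/N=C/c2ccc3ccccc3n2)cc1` gives 20000 nM
compound 3 `CN(C)C(=S)N/N=C/c1ccc2cccnc2n1` gives 970 nM

Compound 2 stands second highest of these three numbers; compound 3 sits far lower, and compound 1 lies higher by a 2.8-fold lower number from compound 1 to compound 2 (0.45 log units; beyond the scatter). Compound 4 `Cc1ccc(NC(=S)N/N=C/c2ccc3ccccc3n2)cc1` differs from compound 2 in one place: methyl in place of cyano on an aromatic carbon. For the measured compounds named here, the only measured step touching this position is the one from compound 1 to compound 2, which was modest and went toward a lower number; no measured step covers methyl itself. A small shift upward is therefore expected, roughly a 1.9-fold higher number from compound 2 to compound 4 (0.28 log units; within the scatter), since methyl in place of cyano removes the group that accompanied the drop from compound 1 to compound 2. Compound 4 is estimated at 38000 nM, within 14000 nM to 100000 nM.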

Compound 4, half-maximal inhibitory concentration: 86000 nM
Compound 4: the middle estimate sits 2.3-fold (0.35 log units) below what was measured; measured number inside the range.
By their numbers in this assay, from the lowest: compound 3; then compound 2; then compounds 1 and 4 (each within the scatter of the next).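

At this place on the ring, this assay now separates cyano from methyl as well as from bromo, with a 4.3-fold higher number from compound 2 to compound 4 (0.63 log units; beyond the scatter). Methyl and bromo cannot be told apart, as a 1.5-fold higher number from compound 1 to compound 4 (0.18 log units; within the scatter) lies within the scatter. Nothing measured here accounts for the difference between cyano and these two groups. On these data alone, whether an amine or a carboxylic acid at this place would read closer to cyano or to methyl and bromo stays open.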